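Extending the ring-nitrogen substituent from ethyl to benzyl

The source may report more compounds than this note shows. Statements on the series, on what has been measured and on what is new or still open speak of the compounds shown alone.

Compound 1 `CO[C@@]12CCN(C)C[C@H]1[C@H](c1ccc(C)cc1)C(C#N)=C(N)O2`: 13200 nM
Compound 2 `CCN1CC[C@@]2(OC)OC(N)=C(C#N)[C@@H](c3ccc(C)cc3)[C@@H]2C1`: 16800 nM

For the measured compounds named here, in a functional assay on trachea (Cavia porcellus) (on this read-out lower numbers stand for stronger inhibition and higher numbers for weaker inhibition), compound 2 gives the highest of the two numbers so far, yet its gap to compound 1 is within the scatter. Compound 3 `CO[C@@]12CCN(Cc3ccccc3)C[C@H]1[C@H](c1ccc(C)cc1)C(C#N)=C(N)O2` carries phenyl in place of methyl on a saturated chain carbon bound to an amine nitrogen in a ring. Going by the values given here, the only measured step at this place, a 1.3-fold higher number from compound 1 to compound 2 (0.10 log units; within the scatter), was small and within the scatter, so there is no sign that this position moves the read-out strongly. A larger entering group is nevertheless a bigger change than that earlier step, so a wide range is appropriate. Compound 3 is therefore expected near 12000 nM, within 3000 nM to 45000 nM, a step of a 1.4-fold lower number from compound 2 to compound 3 (0.15 log units; within the scatter) that is an estimate only.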

Compound 3, half-maximal inhibitory concentration: 27100 nM
Beside the measured number, compound 3's estimate is 2.3-fold (0.35 log units) below it; the range from low to high includes it.
By their numbers in this assay, from the lowest: compounds 1, 2 and 3 (each within the scatter of the next, the first and the last beyond it).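

In this assay, ethyl to benzyl gives a 1.6-fold higher number from compound 2 to compound 3 (0.21 log units; within the scatter), so this change alone does not separate the two compounds. Phenyl in place of hydrogen at the same place gives a 2.1-fold higher number from compound 1 to compound 3 (0.31 log units; beyond the scatter), the first modest step beyond the scatter at this position, and it goes towards weaker inhibition. Nothing available explains this step. Still open, from the compounds shown here alone, is how a longer chain ending in phenyl would read at this place. Going by these compounds, a benzyl carrying an amine or a carboxylic acid on its ring is equally open.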